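A few compounds are considered here, and "the series" means these few. Any claim that something is new, unique, unknown or untested is made for them only; others in the source may bear on it.

Measured so far:
compound 1 `COc1ccc(-n2c(=O)n(Cc3cc4cc(Cl)ccc4n3CCCC#N)c3cnccc32)cc1` — > 50000 nM
compound 2 `O=c1n(Cc2cc3ccncc3n2CCCCO)c2cnccc2n1C1CC1` — > 100000 nM
compound 3 `O=c1n(Cc2cc3cnccc3n2CCCCF)c2cnccc2n1C1CC1` — > 50000 nM

In an ADME assay on HeLa cells (Homo sapiens) for cytotoxicity, read by ATP content, with a stated time of 3 days (a lower number here means that less compound is tolerated, a higher number that more compound is tolerated), compound 1 gives > 50000 nM, which is a limit of the assay and not a number. Compound 2 gives > 100000 nM in this assay, again only a limit. Compound 3 gives > 50000 nM in this assay, likewise a limit. Compound 1 therefore stands at the limit of > 50000 nM in this assay, at which 2 of the 3 values shown sit. Compound 2 stands at the limit of > 100000 nM in this assay, at which 1 of the 3 values shown sits. Going by the values given here, no value in this set is a measured number, so no step between measured compounds can be stated, and nothing in the set marks any compound as more or less tolerated than another.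

Compound 4 `N#CCCCn1c(Cn2c(=O)n(-c3ccncc3)c3ccncc32)cc2cc(Cl)ccc21` has not yet been measured in this assay. It differs from compound 1 in one place: pyridin-4-yl in place of 4-methoxyphenyl on an aromatic nitrogen. Among the compounds with values here, with every value so far sitting at a limit, the expected size of the step is none beyond the scatter, and the most likely outcome is a further limit. Compound 4 is expected to give 80000 nM in this assay, with a range from 30000 nM to 200000 nM. The resulting step that the limit leaves unreadable from compound 1 to compound 4 is expected to stay within the scatter.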

Compound 4, half-maximal cytotoxic concentration: > 50000 nM
Compound 4 ended at the assay's limit (the forecaster's own chance of this, stated with the estimate: 85%); the middle value does not contradict the limit.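

In this assay compound 4 gives > 50000 nM, which is a limit of the assay and not a number. Compound 1 also stands at a limit, so no step can be read between compound 1 and compound 4. The compounds shown leave open what concentration of any of them would reach the half-maximal cytotoxic level.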